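Indole-oxadiazole series: fluoro for methoxy, second occurrence

The compounds below may be only part of what the source reports. "The series", "measured", "known", "first", "only" and "open" are said of these compounds alone.

Measured so far in a functional assay on COLO 320 cells (Homo sapiens) for antiproliferative activity, read by WST assay, with a stated time of 72 h; a lower number here means a stronger inhibitor, a higher number a weaker inhibitor:
compound 1 `COc1ccc2[nH]c(-c3nc(-c4ccccc4)no3)cc2c1`: 18700 nM
compound 2 `Fc1ccc2[nH]c(-c3nc(-c4ccccc4)no3)cc2c1`: 10800 nM
compound 3 `COc1ccc2[nH]c(-c3nc(-c4ccc(Cl)cc4)no3)cc2c1`: 12800 nM

All three numbers sit close together. From compound 1 to compound 2 the change is fluoro in place of methoxy on an aromatic carbon, and this assay shows a 1.7-fold lower number from compound 1 to compound 2 (0.24 log units; within the scatter). From compound 1 to compound 3 the change is chloro in place of hydrogen on an aromatic carbon, giving a 1.5-fold lower number from compound 1 to compound 3 (0.16 log units; within the scatter). Compound 2 and compound 3 give values within the scatter of each other, so no order between them is claimed.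

Compound 4 `Fc1ccc2[nH]c(-c3nc(-c4ccc(Cl)cc4)no3)cc2c1` has not been measured. It differs from compound 3 by fluoro in place of methoxy on an aromatic carbon, the same change that separates compound 1 from compound 2; the two cores differ by the chloro told above. Within the data shown here, the step from compound 3 to compound 4 in this assay is expected to be about the size of the earlier one, since the only measured instance of this change is a 1.7-fold lower number from compound 1 to compound 2 (0.24 log units; within the scatter), and that step lies within the scatter. On that basis compound 4 is estimated at 7500 nM, likely between 3500 nM and 16000 nM, which would mean an expected step of a 1.7-fold lower number from compound 3 to compound 4 (0.23 log units; within the scatter).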

Compound 4, half-maximal inhibitory concentration: > 50000 nM
Compound 4: a limit, no number (the forecaster's own chance of this, stated with the estimate: 5%); middle value at least 6.6-fold (0.82 log units) from the limit.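

In this assay compound 4 gives > 50000 nM, which is a limit of the assay and not a number. Fluoro in place of methoxy gives an at least 3.9-fold higher number from compound 3 to compound 4 (0.59 log units; beyond the scatter), and chloro in place of hydrogen gives an at least 4.6-fold higher number from compound 2 to compound 4 (0.66 log units; beyond the scatter), so in this series neither change carries unchanged from one core to the other, although the full size of each new step stays unread: the same change on two cores in this assay, a 1.7-fold lower number (0.24 log units; within the scatter) from compound 1 to compound 2 and an at least 3.9-fold higher number (0.59 log units; beyond the scatter) from compound 3 to compound 4, at least 6.7-fold (0.83 log units) apart, beyond the scatter of two such steps The two changes therefore do not simply add when combined in compound 4, but this single combination shows neither why that is so nor whether it holds beyond these four compounds: the same change on two cores in this assay, a 1.5-fold lower number (0.16 log units; within the scatter) from compound 1 to compound 3 and an at least 4.6-fold higher number (0.66 log units; beyond the scatter) from compound 2 to compound 4, at least 6.7-fold (0.83 log units) apart, beyond the scatter of two such steps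

The compounds shown leave open whether the same break appears when bromo or methyl stands in the place of the chloro, or whether it is confined to the pairing of chloro and fluoro. They also leave open how an amine or a carboxylic acid in the place of the fluoro would behave alongside the chloro.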